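Urea series on renal carcinoma cells: dropping the chloro

The source may hold more compounds than are shown below. What is called first, only, known or untested is meant among the compounds shown, and "the series" means these compounds.

Measured compounds:
- compound 1, `COc1cc(Cl)cc(-c2nn(-c3cccc(NC(=O)Nc4ccc(Cl)c(C(F)(F)F)c4)c3)cc2-c2ccncc2)c1`: -40%
- compound 2, `COc1cc(Cl)cc(-c2nn(-c3cccc(NC(=O)Nc4cc(C(F)(F)F)cc(C(F)(F)F)c4)c3)cc2-c2ccncc2)c1`: -61%
- compound 3, `COc1cc(Cl)cc(-c2nn(-c3cccc(NC(=O)Nc4ccc(Cl)c(Cl)c4)c3)cc2-c2ccncc2)c1`: -8%

All three share one core and differ only in the aryl group on the far side of the urea. In a functional assay on CAKI-1 cells (Homo sapiens) for inhibition, read by sulforhodamine B assay, with a stated time of 48 h, tested at 100 uM (on this read-out higher numbers stand for a weaker effect at the one concentration tested and lower numbers for a stronger effect), compound 1 stands second highest of the three numbers; compound 2 lies lower, beyond the scatter, and compound 3 lies higher, again beyond the scatter. Within the data shown here, the one step measured between neighbours that differ in a single place is a number 32 percentage points higher from compound 1 to compound 3 (beyond the scatter), which shows that exchanging the group ortho to the chloro shifts the read-out strongly.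

Compound 4, `COc1cc(Cl)cc(-c2nn(-c3cccc(NC(=O)Nc4cccc(C(F)(F)F)c4)c3)cc2-c2ccncc2)c1`, has not been measured. Against compound 1 the change is hydrogen in place of chloro on an aromatic carbon. Among the measured compounds shown here, no measured step removes a substituent outright, so the only guide is the size of the step from compound 1 to compound 3, which says that this part of the molecule is sensitive. Taking the chloro away is expected to move the number upward, and the step of a number 20 percentage points higher from compound 1 to compound 4 (beyond the scatter) is the estimate. Compound 4 is therefore expected to give -20%, within -50% to 10%.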

Compound 4, a percentage reported as activity, at one concentration (the size of the read-out at that concentration, not a potency): -20%
Beside the measured number, compound 4's estimate shows no gap at the digits printed; the measured number falls inside the stated range.
By their numbers in this assay, from the lowest: compound 2; then compound 1; then compound 4; then compound 3.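

In this assay, among these compounds, the carbon para to a large group is varied for the first time, and losing its chloro alone gives a number 20 percentage points higher from compound 1 to compound 4 (beyond the scatter) on the weaker side of the read-out. The aryl group with a single trifluoromethyl still reads stronger than 3,4-dichlorophenyl, with a number 12 percentage points lower from compound 3 to compound 4 (beyond the scatter) as the step. Hydrogen in place of a trifluoromethyl of compound 2 gives a number 41 percentage points higher from compound 2 to compound 4 (beyond the scatter) and is the one large step among the new ones, so in this small set a second substituent helps with chloro or trifluoromethyl as that substituent, while compound 3 goes against this.

From the compounds shown here alone, whether a fluoro, a methoxy or an amine on this carbon would read closer to the chloro or to the hydrogen stays open. Nothing at hand explains the direction or size of these steps.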